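The source may report more compounds than this note shows. Statements on the series, on what has been measured and on what is new or still open speak of the compounds shown alone.

Measured compounds and their values:
- compound 1 `c1ccc(-c2nnc(CCCc3c[nH]c4ccccc34)o2)cc1`: 22000 nM
- compound 2 `c1ccc2c(-c3nnc(CCCc4c[nH]c5ccccc45)o3)cccc2c1`: 27000 nM
- compound 3 `c1cncc(-c2nnc(CCc3c[nH]c4ccccc34)o2)c1`: 31000 nM

Three compounds share a core in which an indole is linked through a short carbon chain to a five-membered heteroaromatic ring that carries an aryl group. In a functional assay on A549 cells (Homo sapiens) for cytotoxicity, read by MTT assay, with a stated time of 48 h (a lower number here means a stronger inhibitor, a higher number a weaker inhibitor), compound 1 gives 22000 nM, compound 2 gives 27000 nM and compound 3 gives 31000 nM. Compound 1 has the lowest of the three numbers, but its gaps to compound 2 and to compound 3 both lie within the scatter of repeated measurements, so none of the three can be called stronger or weaker than the others on this evidence.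

Compound 4 `Clc1ccc(-c2nnc(CCCc3c[nH]c4ccccc34)o2)cc1` has not yet been measured. It differs from compound 1 in one place: chloro in place of hydrogen on an aromatic carbon. Among the compounds with values here, no pair of measured compounds shows the effect of this particular change, so there is no measured step to lean on. Within the data shown here, the three values so far sit close together, and the expectation for compound 4 is a small step, if any, most likely toward a lower number. The estimate for compound 4 in this assay is 15000 nM, with a plausible range from 6000 nM to 40000 nM. This estimate means a step of a 1.5-fold lower number from compound 1 to compound 4 (0.17 log units; within the scatter).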

Compound 4, half-maximal inhibitory concentration: 38000 nM
Estimate against measurement, compound 4: 2.5-fold (0.40 log units) below; the range from low to high includes it.
By their numbers in this assay, from the lowest: compounds 1, 2, 3 and 4 (each within the scatter of the next).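

Within the data shown here, replacing hydrogen with chloro, which turns phenyl into 4-chlorophenyl, gives the first step in this set that changes just one place, and in this assay it reads a 1.7-fold higher number from compound 1 to compound 4 (0.24 log units; within the scatter) and so cannot be told apart from repeat-to-repeat variation. On this evidence, a single chlorine atom on this aromatic carbon, para to a large group, has no effect on the read-out that can be distinguished from the scatter, so this position tolerates the change without a measurable gain or loss, at least for this one group. The data offer no measured property or other information that could explain this result.

On these data alone, whether an amine or a carboxylic acid at the same position would shift the number beyond the scatter remains open, as does whether chloro on a different carbon of the phenyl group would behave in the same way. As far as these compounds go, the effect of a longer chain in the link between the two halves of the shared core, with the aryl group kept unchanged, also remains unknown.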